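Working notes: chloro removed from the anilino group

This account rests on a few compounds, and the source may have more. Where it says the series, first, only, none or still open, it means among the compounds named here.

Measured so far:
- Compound 1 `COc1cccc(/C=C/C(=O)c2sc(Nc3ccc(Cl)cc3)nc2C)c1`. In a functional assay on Bel-7402 cells (Homo sapiens) for cytotoxicity, read by MTT assay (a higher number here means a weaker inhibitor, a lower number a stronger inhibitor), compound 1 gives > 25000 nM, a limit of the assay and not a number.
- Compound 2 `COc1cc(/C=C/C(=O)c2sc(Nc3ccc(Cl)cc3)nc2C)cc(OC)c1OC`. In this assay compound 2 gives > 25000 nM, again a limit of the assay and not a number.

Compound 2 thus stands where every value shown sits, (the limit of > 25000 nM in this assay, at which 2 of the 2 values shown sit). Among the measured compounds shown here, the two values show only that neither compound 1 nor compound 2 reaches a measurable concentration in this assay; no step between them is given.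

Compound 3 `COc1cc(/C=C/C(=O)c2sc(Nc3ccccc3)nc2C)cc(OC)c1OC` differs from compound 2 by hydrogen in place of chloro on an aromatic carbon of a six-membered aromatic ring of carbon only, para to a large group. For the measured compounds named here, no measured pair shows the effect of such a change. With compound 2 sitting at the limit of this assay, the step is expected to be none beyond the scatter, a step that the limit leaves unreadable from compound 2 to compound 3. Compound 3 is expected to give 35000 nM, within 12000 nM to 100000 nM, most probably reported once more only as a limit.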

Compound 3, half-maximal inhibitory concentration: > 25000 nM
Compound 3: no number, only a limit (the forecaster's own chance of this, stated with the estimate: 80%); the middle value is on the limit's open side.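

No step can be read between compound 2 and compound 3, since both values are limits of the assay and not numbers: the limit of > 25000 nM in this assay, at which 3 of the 3 values shown sit.

The compounds shown leave open whether hydrogen or chloro on the anilino group makes any difference, and whether any compound of this series gives a numerical value in this assay.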